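The source may hold more compounds than are shown below. What is called first, only, known or untested is meant among the compounds shown, and "the series" means these compounds.

Measured compounds:
compound 1 `ClCc1cccc(Cn2cnc3nc(Cl)nc(Cl)c32)c1` with 17400 nM
compound 2 `ClCc1ccccc1Cn1cnc2ncnc(Cl)c21` with 3230 nM
compound 3 `ClCc1ccccc1Cn1cnc2c(Cl)nc(Cl)nc21` with 420 nM

In a functional assay on UO-31 cells (Homo sapiens) for cytotoxicity, read by sulforhodamine B assay, with a stated time of 48 h (a higher number here means a weaker inhibitor of growth, a lower number a stronger inhibitor of growth), compound 1 gives the highest of the three numbers; compound 2 sits well below it, and compound 3 lies furthest below, both gaps beyond the scatter. Compound 4 `ClCc1cccc(Cn2cnc3ncnc(Cl)c32)c1` has not yet been measured in this assay. It differs from compound 1 by hydrogen in place of chloro on an aromatic carbon, the place being an aromatic carbon of the six-membered ring with two nitrogen, between two ring nitrogen atoms. Among the measured compounds shown here, no single step of this kind among the measured compounds is available, so the expectation rests on the set as a whole, in which the dichloro compound 3 gives the lowest number and the monochloro compound 2 a higher one. The step from compound 1 to compound 4 in this assay is therefore expected to be small and toward a higher number, a 1.4-fold higher number from compound 1 to compound 4 (0.16 log units; within the scatter). Compound 4 is estimated at 25000 nM, within 8000 nM to 80000 nM.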

Compound 4, concentration for 50% growth inhibition: 1540 nM
The estimate for compound 4 lay 16-fold (1.21 log units) above the measured number; the measured number lies below the stated range.
By their numbers in this assay, from the lowest: compound 3; then compound 4; then compound 2; then compound 1.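

Among the compounds shown here, replacing chloro with hydrogen on the aromatic carbon between two ring nitrogen atoms gives, in this assay, an 11-fold lower number from compound 1 to compound 4 (1.05 log units; beyond the scatter), the first step in the set that changes a single place. In this pair, growth inhibition does not depend on the chloro group at this position, and removing it gives the stronger inhibitor. Nothing measured here accounts for the size of this step. 

As far as these compounds go, it remains open whether an amine or a methoxy group at this position would give a number closer to that of compound 4 or of compound 1. From the compounds shown here alone, whether the same change has a similar effect on compound 3 also remains open.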